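From Methyl to Phenyl on a Four-Nitrogen Ring

The compounds below may be only part of what the source reports. "The series", "measured", "known", "first", "only" and "open" are said of these compounds alone.

Measured compounds:
Compound 1, `Cc1nc(C)c(CNC(=O)CN2CCCC2=O)nc1C` — 23.4%
Compound 2, `C=CCc1ccc(OCc2nc(C)c(C)nc2C)c(OC)c1` — 30.1%
Compound 3, `Cc1nc(C)c(CSc2nnnn2C)nc1C` — -77%

In a functional assay on ECV-304 cells (Homo sapiens), read by MTT assay, with stated times of 24 h and 12 h, tested at 50 uM (on this read-out lower numbers stand for a weaker effect and higher numbers for a stronger effect at the one concentration tested), compound 1 gives 23.4% and compound 2 gives 30.1%, while compound 3 gives -77%. Compound 3 therefore stands lowest of the three numbers: the nearest is compound 1, whose number lies above it by a gap beyond the scatter, and the furthest is compound 2, higher still. Among the measured compounds shown here, the three share the same core, but no two of them differ in only one place, so no measured pair shows how a single change shifts this read-out.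

Compound 4, `Cc1nc(C)c(CSc2nnnn2-c2ccccc2)nc1C`, has not been measured. It differs from compound 3 in one spot: phenyl in place of methyl on an aromatic nitrogen.

For the measured compounds named here, with no comparable step on record, the size of this change in this assay is open. Because compound 3 gives -77% and the two other compounds sit well above it, the step is expected to run upward, by a number 47 percentage points higher from compound 3 to compound 4 (beyond the scatter), though a shift of either sign would not be surprising. Compound 4 is accordingly estimated at -30%, with a range from -95% to 35%.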

Compound 4, a percentage reported as activity, at one concentration (the size of the read-out at that concentration, not a potency): -78.4%
The estimate for compound 4 lay 48.4 percentage points above the measured number; the range from low to high includes it.
By their numbers in this assay, from the lowest: compounds 4 and 3 (each within the scatter of the next); then compounds 1 and 2 (each within the scatter of the next).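

In this assay, among the compounds shown here, placing phenyl in place of methyl on an aromatic nitrogen of the five-membered aromatic ring with 4 nitrogen gives a number 1.4 percentage points lower from compound 3 to compound 4 (within the scatter) and so offers the first comparison here of compounds that differ in one place. At this position, a group with a six-membered aromatic ring can stand where methyl, which has no ring, stood, with no shift beyond the usual scatter at the one concentration tested. No measurement at hand bears on the reason for this result.

The compounds shown leave open whether this position would stay as unresponsive with an amine, a carboxylic acid or a longer chain such as butyl on the same nitrogen. They also leave open whether a phenyl ring carrying a methoxy group would read the same way.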